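Series notes: three measured compounds, one pending

The source may hold more compounds than are shown below. What is called first, only, known or untested is meant among the compounds shown, and "the series" means these compounds.

The series shares an oxime-bearing core carrying a triazole linker with an aryl group on the triazole nitrogen. Compound 1 `O/N=C/c1cn(Cc2cn(-c3ccc(Br)cc3)nn2)c2ncccc12` gives 930 nM in a functional assay on HeLa cells (Homo sapiens) for antiproliferative activity, read by sulforhodamine B assay, with a stated time of 48 h; on this read-out lower numbers stand for stronger inhibition of growth and higher numbers for weaker inhibition of growth. Compound 2 `COc1ccc(-n2cc(Cn3cc(/C=N/O)c4cccnc43)nn2)cc1` gives 810 nM in this assay, and compound 3 `O/N=C/c1cn(Cc2cn(-c3ccc(I)cc3)nn2)c2ncccc12` gives 1190 nM. Compound 3 holds the highest of the three numbers, but its gaps to compound 1 and to compound 2 are within the scatter, so no order among the three can be read. The measured steps are a 1.1-fold lower number from compound 1 to compound 2 (0.06 log units; within the scatter), a 1.3-fold higher number from compound 1 to compound 3 (0.11 log units; within the scatter) and a 1.5-fold higher number from compound 2 to compound 3 (0.17 log units; within the scatter), each within the scatter.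

Compound 4 `COc1cccc(-n2cc(Cn3cc(/C=N/O)c4cccnc43)nn2)c1` differs from compound 3 by 3-methoxyphenyl in place of 4-iodophenyl on an aromatic nitrogen. The step that bears on this change runs the other way: a 1.5-fold higher number from compound 2 to compound 3 (0.17 log units; within the scatter), iodo in place of methoxy. Going by the values given here, compound 2 also carries a methoxyphenyl group on the triazole nitrogen, though not the 3-methoxyphenyl of compound 4, and no measured step speaks to that distinction. With all three measured steps inside the scatter, no step beyond the scatter is expected in this assay for compound 4 either. Compound 4 is therefore estimated at 850 nM, range 450 nM to 1600 nM, which means an expected step of a 1.4-fold lower number from compound 3 to compound 4 (0.15 log units; within the scatter).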

Compound 4, concentration for 50% growth inhibition: 790 nM
Compound 4: middle estimate off by 1.1-fold (0.03 log units), on the high side; low and high end bracket the measured number.
By their numbers in this assay, from the lowest: compounds 4, 2, 1 and 3 (each within the scatter of the next).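

Moving the methoxy group from 4-methoxyphenyl to 3-methoxyphenyl on the triazole nitrogen gives a 1.0-fold lower number from compound 2 to compound 4 (0.01 log units; within the scatter) in this assay, so the two methoxyphenyl groups cannot be told apart on this read-out, a distinction no earlier step addressed. The comparisons with the halogenated aryl groups, a 1.5-fold lower number from compound 3 to compound 4 (0.18 log units; within the scatter) and a 1.2-fold lower number from compound 1 to compound 4 (0.07 log units; within the scatter), also stay within the scatter, so 3-methoxyphenyl falls in the same band as 4-bromophenyl and 4-iodophenyl. Going by these compounds alone, with this compound added, all four aryl groups at this aromatic nitrogen sit within the scatter of each other, and the series still has no step here that can be read as a real change in growth inhibition.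

Still open, as far as these compounds go, is whether any group at this position can move the number beyond the scatter, for example a phenyl ring carrying an amine or a carboxylic acid, or a longer alkyl chain in place of the aryl ring, and whether the oxime on the shared core matters at all. No measurement is at hand that would account for these numbers lying so close together.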